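Quinazolin-4-yl for Pyridin-2-yl on the Ether Oxygen

The compounds below may be only part of what the source reports. "The series", "measured", "known", "first", "only" and "open" are said of these compounds alone.

Working notes on the series. The compounds share one core, seen in compound 1 `CC(C)[C@H](NC(=O)COc1cccc2ccccc12)C(=O)N[C@@H](CC(=O)O)C(=O)CSc1ncc[nH]1`, compound 2 `CC(C)[C@H](NC(=O)COc1cccc2ccccc12)C(=O)N[C@@H](CC(=O)O)C(=O)CSc1nnnn1-c1ccccc1` and compound 3 `CC(C)[C@H](NC(=O)COc1cccc2ccccc12)C(=O)N[C@@H](CC(=O)O)C(=O)COc1ccccn1`. In a functional assay on Jurkat cells (Homo sapiens) for inhibition (a higher number here means a weaker inhibitor, a lower number a stronger inhibitor), compound 3 gives only a limit, > 200000 nM. Compound 1 likewise gives only a limit, > 200000 nM. Compound 2 gives 153000 nM, and the step of an at least 1.3-fold higher number from compound 2 to compound 3 (0.11 log units; that floor lies within the scatter) stays within the scatter, while the step that the two limits leave unreadable from compound 1 to compound 3 cannot be read, as the limit of > 200000 nM in this assay, at which 2 of the 3 values shown sit, shows. Compound 4 `CC(C)[C@H](NC(=O)COc1cccc2ccccc12)C(=O)N[C@@H](CC(=O)O)C(=O)COc1ncnc2ccccc12` differs from compound 3 by quinazolin-4-yl in place of pyridin-2-yl on an oxygen on a saturated carbon. Within the data shown here, no measured step changes a group on the oxygen; the closest comparison, an at least 1.3-fold lower number from compound 1 to compound 2 (0.11 log units; that floor lies within the scatter), stays within the scatter. No step beyond the scatter is therefore expected, and the estimate for compound 4 is 150000 nM, between 50000 nM and 300000 nM. The step expected is an at least 1.3-fold lower number from compound 3 to compound 4 (0.12 log units; that floor lies within the scatter).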

Compound 4, half-maximal inhibitory concentration: > 200000 nM
Compound 4 ended at the assay's limit; the forecaster's own chance of this, stated with the estimate: 55%; at least 1.3-fold (0.12 log units) between middle value and limit.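

With quinazolin-4-yl in place of pyridin-2-yl on the oxygen, compound 4 in this assay still gives only a limit, > 200000 nM. Both groups on this oxygen now end at that limit, and the steps to compound 4 from compound 1 and compound 3 cannot be read: the limit of > 200000 nM in this assay, at which 3 of the 4 values shown sit.

Among these compounds, the one readable step, an at least 1.3-fold higher number from compound 2 to compound 4 (0.11 log units; that floor lies within the scatter), stays within the scatter.

Going by these compounds, how far compound 3 and compound 4 lie from each other stays open. So does what an amine or a carboxylic acid in place of quinazolin-4-yl on this oxygen would give.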